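The source may hold more compounds than are shown below. What is called first, only, known or untested is meant among the compounds shown, and "the series" means these compounds.

Within the data shown here, this account concerns two compounds assessed in a functional assay on SW480 cells (Homo sapiens) for antiproliferative activity, read by MTT assay, with a stated time of 72 h (on this read-out higher numbers stand for weaker inhibition and lower numbers for stronger inhibition), and a third for which no measurement yet exists. Compound 1 `Cc1ccc2c(=O)c(CSC(=S)N3CCCCC3)coc2c1` and compound 2 `CCOC(=O)c1cc(=O)c2cc(CSC(=S)N(C(C)C)C(C)C)ccc2o1` each carry a thiocarbonyl carbon bearing a sulfur and an amino group, but differ in their cores and in that amino group. In this assay compound 1 gives > 25000 nM, which is a limit of the assay rather than a number. In this assay compound 2 likewise gives > 25000 nM, again a limit of the assay and not a number. Among the measured compounds shown here, both values fall under (the limit of > 25000 nM in this assay, at which 2 of the 2 values shown sit), so no order between compound 1 and compound 2 can be read, and no step between them exists.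

Compound 3 `CCOC(=O)c1cc(=O)c2cc(CSC(=S)N(C)c3ccccc3)ccc2o1` keeps the core of compound 2 and differs from it at a single place: methyl(phenyl)amino in place of diisopropylamino on a thiocarbonyl carbon. With both measured values at a limit, the data give no foothold for a gain in this assay. The step expected a step that the limit leaves unreadable from compound 2 to compound 3 is none beyond the scatter. Compound 3 is therefore estimated to give 30000 nM in this assay, with a range from 10000 nM to 100000 nM, and most likely only a limit will be reported once more.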

Compound 3, half-maximal inhibitory concentration: > 25000 nM
Compound 3: a limit, no number; the forecaster's own chance of this, stated with the estimate: 80%; the middle value is on the limit's open side.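

In this assay compound 3 gives > 25000 nM, again a limit of the assay and not a number. No step can be read between compound 2 and compound 3, and all the compounds shown sit at one limit: the limit of > 25000 nM in this assay, at which 3 of the 3 values shown sit. The compounds shown leave open what number each would give in this assay, and whether the amino group or the core has any bearing on it.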